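Methyl for trifluoromethyl on the shared core: expected inhibition

The source may hold more compounds than are shown below. What is called first, only, known or untested is meant among the compounds shown, and "the series" means these compounds.

Measured so far:
compound 1 `Cc1ccc2nc(-c3ccccc3N(C)C)[nH]c(=O)c2c1` — in an assay on isolated protein for inhibition of DNA topoisomerase 1 (Homo sapiens), with a stated time of 30 min, tested at 100 uM (on this read-out higher numbers stand for a stronger effect at the one concentration tested and lower numbers for a weaker effect), compound 1 gives 82.9%
compound 2 `Cc1ccc2nc(-c3ccccc3C(F)(F)F)[nH]c(=O)c2c1` — in this assay compound 2 gives 72%

Among the compounds with values here, compound 2 stands lowest of the two numbers; its nearest neighbour is compound 1, the only measured step being a number 10.9 percentage points lower from compound 1 to compound 2 (beyond the scatter). Compound 3 `Cc1ccc2nc(-c3ccccc3C)[nH]c(=O)c2c1` differs from compound 2 by methyl in place of trifluoromethyl on an aromatic carbon. Within the data shown here, the one measured step exchanges dimethylamino for trifluoromethyl, a different change from the one in hand, so it bears on the new step only loosely: it shows that a swap of the group at this place can move this assay beyond the scatter, but it does not tell in which direction the present swap goes. Among the measured compounds shown here, with no closer precedent, the step expected for a number 3 percentage points higher from compound 2 to compound 3 (within the scatter) is within the scatter or slightly upward, with wide uncertainty. Compound 3 is therefore estimated at 75%, with a range of 55% to 90%.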

Compound 3, a percentage reported as inhibition, at one concentration (the size of the read-out at that concentration, not a potency): 0%
For compound 3 the middle estimate is 75 percentage points above the measured one; measured number outside the range, below it.
By their numbers in this assay, from the lowest: compound 3; then compound 2; then compound 1.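

Methyl in place of trifluoromethyl, on an aromatic carbon ortho to a large group, gives a number 72 percentage points lower from compound 2 to compound 3 (beyond the scatter) in this assay, and methyl in place of dimethylamino gives a number 82.9 percentage points lower from compound 1 to compound 3 (beyond the scatter). The group at this place can therefore do far more than the step between compound 1 and compound 2 suggested: trifluoromethyl and dimethylamino both retain clear inhibition, whereas methyl in compound 3 gives 0%. No measurement at hand accounts for this loss.

The compounds shown leave open whether the loss is particular to methyl or extends to other groups at this place. A methoxy group, an ethyl group, a primary amine or plain hydrogen there would begin to settle this, and compounds with such groups would show whether inhibition returns.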